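The source may hold more compounds than are shown below. What is called first, only, known or untested is meant among the compounds shown, and "the series" means these compounds.

Of the compounds shown here, two have been measured in a functional assay on NCI-H460 cells (Homo sapiens) for antiproliferative activity; a higher number here means a weaker inhibitor, a lower number a stronger inhibitor. Compound 1, `CN(C)c1ccc(/C=C2/SC(=Nc3ccccc3)NC2=O)cc1`, gives 210 nM and so stands with the lowest number of the two. Compound 2, `COc1ccc(/C=C2/S/C(=N/c3ccccc3C)NC2=O)cc1`, gives 1700 nM in this assay; it differs from compound 1 in more than one place, so the gap between these two values cannot be tied to any single change. Compound 3, `CN(C)c1ccc(/C=C2/SC(=Nc3ccccc3Cl)NC2=O)cc1`, has not yet been measured. It differs from compound 1 in one place: chloro in place of hydrogen on an aromatic carbon. Within the data shown here, no measured pair shows this change alone, so there is no step to read from. The expectation is a small change in this assay, if any beyond the usual scatter, leaning slightly toward a higher number. Compound 3 is therefore estimated at about 300 nM, within 120 nM to 800 nM. That estimate means an expected step of a 1.4-fold higher number from compound 1 to compound 3 (0.15 log units; within the scatter).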

Compound 3, half-maximal inhibitory concentration: 880 nM
Beside the measured number, compound 3's estimate is 2.9-fold (0.47 log units) below it; measured number outside the range, above it.
By their numbers in this assay, from the lowest: compound 1; then compounds 3 and 2 (each within the scatter of the next).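

Among these compounds, the first step that isolates a single change comes with phenyl becoming 2-chlorophenyl: in this assay there is a 4.2-fold higher number from compound 1 to compound 3 (0.62 log units; beyond the scatter). This shows that a chloro on this aromatic ring, ortho to a large group, comes at a modest cost in potency, so even one added heavy atom at this position can move the result beyond the usual scatter. No available data on the compounds' properties or on how they act bear on this loss.

As far as these compounds go, what remains open is whether the loss is specific to chloro or would appear with any group at this position. A fluoro or a methoxy at the same place would help to answer that, and a chloro elsewhere on this ring would show whether the position matters.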